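A few compounds are considered here, and "the series" means these few. Any claim that something is new, unique, unknown or untested is made for them only; others in the source may bear on it.

Compound 1 `CC(C)c1n[nH]c2c(NCc3ccc(-c4ccccn4)cc3)nc(SCCO)nc12`: 48 nM
Compound 2 `CC(C)c1n[nH]c2c(NCc3ccc(-c4ccccn4)cc3)nc(SCC(C)(C)O)nc12`: 507 nM
Compound 3 `CC(C)c1n[nH]c2c(NCc3ccc(-c4ccccn4)cc3)nc(SCCNC(=N)N)nc12`: 390 nM

These three compounds share the same core and differ only in the group carried on its sulfur. Their effect on cell growth was measured in a functional assay on HT cells (Homo sapiens) for antiproliferative activity, read by fluorescence, with a stated time of 72 h; on this read-out higher numbers stand for weaker inhibition of growth and lower numbers for stronger inhibition of growth. Compound 2 gives the highest of the three numbers: there is an 11-fold higher number from compound 1 to compound 2 (1.02 log units; beyond the scatter), whereas against compound 3 the gap lies within the scatter, a 1.3-fold lower number from compound 2 to compound 3 (0.11 log units; within the scatter).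

The compound now considered, compound 4 `CC(C)c1n[nH]c2c(NCc3ccc(-c4ccccn4)cc3)nc(S)nc12`, has not yet been measured. It differs from compound 2 in one place: hydrogen in place of 2-hydroxy-2-methylpropyl on a sulfur. Among the measured compounds shown here, no measured step strips the sulfur down to a bare hydrogen, so none bears on this change directly. The steps that exist show that what sits on the sulfur can matter: an 11-fold higher number from compound 1 to compound 2 (1.02 log units; beyond the scatter) and an 8.1-fold higher number from compound 1 to compound 3 (0.91 log units; beyond the scatter) were both beyond the scatter, while a 1.3-fold lower number from compound 2 to compound 3 (0.11 log units; within the scatter) was not. In this assay the step to compound 4 could therefore go in either direction, and a wide range is needed. The estimate for compound 4 is 300 nM, between 60 nM and 1500 nM. This corresponds to an expected step of a 1.7-fold lower number from compound 2 to compound 4 (0.23 log units; within the scatter), not expected to reach clearly beyond the scatter.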

Compound 4, concentration for 50% growth inhibition: 2760 nM
Estimate against measurement, compound 4: 9.2-fold (0.96 log units) below; measured number above the stated range.
By their numbers in this assay, from the lowest: compound 1; then compounds 3 and 2 (each within the scatter of the next); then compound 4.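

In this assay, taking the whole group off the sulfur and leaving only hydrogen weakens growth inhibition in every comparison available: a 5.4-fold higher number from compound 2 to compound 4 (0.74 log units; beyond the scatter), a 7.1-fold higher number from compound 3 to compound 4 (0.85 log units; beyond the scatter) and a 58-fold higher number from compound 1 to compound 4 (1.76 log units; beyond the scatter). Among the compounds shown here, the earlier compounds showed only that the groups on the sulfur differ from one another, whereas compound 4 shows that each of the three carries a lower number than the bare sulfanyl compound, with none of the three going against this. The loss is largest against the 2-hydroxyethyl of compound 1, so the size of the penalty for removal depends on which group is taken away, and no measurement shown here bears on why this happens.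

Still open, on these data alone, is whether a simple methyl or ethyl on the sulfur, with no hydroxyl or nitrogen at all, would behave like compound 1 or like compound 4, which would separate the effect of having a chain from that of what ends it. Also open, as far as these compounds go, is how a longer chain ending in hydroxyl, an amine or a carboxylic acid would compare with the 2-hydroxyethyl of compound 1.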